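A few compounds are considered here, and "the series" means these few. Any claim that something is new, unique, unknown or untested is made for them only; others in the source may bear on it.

Going by the values given here, in a physicochemical assay for solubility, read by HPLC (a higher number here means a more soluble compound, a lower number a less soluble compound), compound 1 (`COc1ncc(-c2ccc(-c3cnc4c(c3)CN(C)C4=O)s2)cc1NS(=O)(=O)c1ccccc1[N+](=O)[O-]`) gives 4810 ug/mL and stands in the middle of the three compounds measured so far. Compound 2 (`O=C1NCc2cc(-c3ccc(-c4cncc(NS(=O)(=O)c5ccc(F)cc5F)c4)s3)cnc21`) lies lower at 1130 ug/mL and compound 3 (`CN1Cc2cc(-c3ccc(-c4cncc(NS(=O)(=O)c5cccc(C(F)(F)F)c5)c4)s3)cnc2C1=O`) lies higher at 20300 ug/mL in the same test, and both gaps from compound 1 are beyond the usual scatter of repeated measurements.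

The next compound, compound 4 (`COc1ncc(-c2ccc(-c3cnc4c(c3)CN(C)C4=O)s2)cc1NS(=O)(=O)c1ccccc1C(F)(F)F`), keeps everything in compound 1 except one group: trifluoromethyl takes the place of nitro on an aromatic carbon (trifluoromethyl in place of nitro on an aromatic carbon). Among the compounds with values here, no two measured compounds differ in only one place, so this swap has no direct precedent. Compound 3 also carries a trifluoromethyl and gives 20300 ug/mL but differs from compound 1 in other places too, which makes it only a weak guide.

A slight rise is the best guess, and the expected change is a 1.2-fold higher number from compound 1 to compound 4 (0.10 log units; within the scatter) and so stays within the scatter. Compound 4 is estimated at 6000 ug/mL with an expected range from 1500 ug/mL to 20000 ug/mL when measured.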

Compound 4, solubility: 7340 ug/mL
Beside the measured number, compound 4's estimate is 1.2-fold (0.09 log units) below it, and the stated range covers the measured number.
By their numbers in this assay, from the lowest: compound 2; then compounds 1 and 4 (each within the scatter of the next); then compound 3.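

In this assay, going by these compounds alone, replacing nitro with trifluoromethyl on this aromatic carbon, ortho to a large group, gives a 1.5-fold higher number from compound 1 to compound 4 (0.18 log units; within the scatter), the first step that can be read at a single place. At this position, then, the two groups cannot be told apart by this test, even though nitro counts 2 hydrogen-bond acceptors and trifluoromethyl 0. Nothing measured here offers an explanation for this result.

The compounds shown leave open whether an amine or a carboxylic acid at this same position would also fall within the scatter of compound 1. Also open is which of the several places where compound 2 and compound 3 differ from compound 1 accounts for their distance from it.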